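Swapping chloro for trifluoromethyl on the urea aryl group

This account rests on a few compounds, and the source may have more. Where it says the series, first, only, none or still open, it means among the compounds named here.

Measured so far:
- compound 1 `O=C(Nc1cccc(-n2cc(-c3ccncc3)c(-c3ccc(Cl)c(O)c3)n2)c1)Nc1cccc(C(F)(F)F)c1`: 7650 nM
- compound 2 `COc1cc(-c2nn(-c3cccc(NC(=O)Nc4ccc(Cl)c(Cl)c4)c3)cc2-c2ccncc2)ccc1Cl`: 2470 nM
- compound 3 `O=C(Nc1cccc(-n2cc(-c3ccncc3)c(-c3ccc(Cl)c(O)c3)n2)c1)Nc1ccc(Cl)c(Cl)c1`: 9680 nM

All three share one core and were tested in a functional assay on U-251 cells (Homo sapiens) for inhibition, read by sulforhodamine B assay, with a stated time of 48 h; on this read-out lower numbers stand for stronger inhibition of growth and higher numbers for weaker inhibition of growth. Compound 3 stands at the weaker end of this small set: its number sits well beyond the scatter above that of compound 2 (a 3.9-fold higher number from compound 2 to compound 3 (0.59 log units; beyond the scatter)), while its gap to compound 1 is within the scatter (a 1.3-fold higher number from compound 1 to compound 3 (0.10 log units; within the scatter)).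

Compound 4 `O=C(Nc1cccc(-n2cc(-c3ccncc3)c(-c3ccc(Cl)c(O)c3)n2)c1)Nc1ccc(Cl)c(C(F)(F)F)c1` differs from compound 3 in one place: trifluoromethyl in place of chloro on an aromatic carbon. For the measured compounds named here, the one measured step that bears on this is the exchange on the same amide-type nitrogen, which showed a 1.3-fold higher number from compound 1 to compound 3 (0.10 log units; within the scatter), a change within the scatter. Compound 4 carries both the chloro and the trifluoromethyl, so nothing in the data points to a step beyond the scatter in either direction. Compound 4 is therefore expected to show a 1.3-fold lower number from compound 3 to compound 4 (0.11 log units; within the scatter), with an estimated value of 7500 nM in this assay, in a range from 3000 nM to 20000 nM.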

Compound 4, concentration for total growth inhibition: 1230 nM
The estimate for compound 4 lay 6.1-fold (0.79 log units) above the measured number; measured number outside the range, below it.
By their numbers in this assay, from the lowest: compounds 4 and 2 (each within the scatter of the next); then compounds 1 and 3 (each within the scatter of the next).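

Putting trifluoromethyl on this aromatic carbon in place of chloro produces a clear gain in growth inhibition (a 7.9-fold lower number from compound 3 to compound 4 (0.90 log units; beyond the scatter)), although the earlier exchange between the 3-(trifluoromethyl)phenyl and 3,4-dichlorophenyl groups had stayed within the scatter. Adding chloro to the 3-(trifluoromethyl)phenyl group of compound 1 also gives a clear step (a 6.2-fold lower number from compound 1 to compound 4 (0.79 log units; beyond the scatter)), so among these compounds the lower number appears only when chloro and trifluoromethyl sit together in the 4-chloro-3-(trifluoromethyl)phenyl group. The data shown offer no explanation for this result.

On these data alone, how a bromo or a nitrile on this same carbon would compare remains open. Also open, as far as these compounds go, is whether a methyl on the oxygen of compound 4, the change that separates compound 3 from compound 2, would lower its number further.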